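The source may report more compounds than this note shows. Statements on the series, on what has been measured and on what is new or still open speak of the compounds shown alone.

In a toxicity assay on MDCK cells (Canis lupus familiaris) for cytotoxicity, read by crystal violet staining, with a stated time of 48 h (a lower number here means that less compound is tolerated, a higher number that more compound is tolerated), compound 1 `Cc1ccc2cc(CN(Cc3ccc(F)cc3)Cc3ccc(C(C)(C)C)cc3)c(=O)[nH]c2c1` gives > 33000 nM as a limit and not a number. Compound 2 `Cc1ccc2cc(CN(Cc3ccc(F)cc3)C(=O)c3ccccc3)c(=O)[nH]c2c1` gives > 33000 nM as a limit too. All that is known so far is the limit of > 33000 nM in this assay, at which 2 of the 2 values shown sit, and no more. Compound 3 `Cc1ccc2cc(CN(Cc3ccc(C(C)(C)C)cc3)C3CCCC3)c(=O)[nH]c2c1` has cyclopentyl in place of 4-fluorobenzyl on an amine nitrogen and keeps the 4-(tert-butyl)benzyl group and the shared core of compound 1. Among the measured compounds shown here, the one measured step from compound 1, a step that the two limits leave unreadable from compound 1 to compound 2 with benzoyl in place of 4-(tert-butyl)benzyl on an amine nitrogen, concerns a different group and gives no size to carry over. No shift beyond the scatter is therefore expected in this assay and no direction can be argued. The expected step is a number no higher from compound 1 to compound 3 (the limit leaves the size open) on this estimate. For compound 3 the estimated value is 33000 nM with an expected range from 14000 nM to 50000 nM and a reading at the limit is likely.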

Compound 3, half-maximal cytotoxic concentration: > 10000 nM
Compound 3: a limit, no number; the forecaster's own chance of this, stated with the estimate: 70%; the middle value is on the limit's open side.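

In this assay compound 3 gives > 10000 nM, a limit and not a number. Among the compounds shown here, compound 1 also stands at a limit, and no step from compound 1 to compound 3 can be read. The compounds shown leave open where any of them becomes cytotoxic.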